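The source may report more compounds than this note shows. Statements on the series, on what has been measured and on what is new or still open speak of the compounds shown alone.

Three compounds set the scene in an assay on CHO cells for displacement of a labelled ligand from prostaglandin E2 receptor EP3 subtype (Homo sapiens), read by radioligand binding; on this read-out lower numbers stand for stronger inhibition and higher numbers for weaker inhibition. Compound 1 `CCn1ncc2c(F)cc(-c3ccc(C(CC)(CC)c4nncn4C)c(=O)[nH]3)cc21` gives 54 nM, compound 3 `CCn1ncc2c(F)cc(-c3ccc(C(CC)(CC)c4ncn(C)n4)c(=O)[nH]3)cc21` gives 39 nM, and compound 2 `CC(C)C(c1nnc[nH]1)c1ccc(-c2ccc3cccc(F)c3c2)[nH]c1=O` gives 12 nM, the lowest number of the three, with both other values lying beyond the scatter above it. Among the measured compounds shown here, the only measured step, a 1.4-fold lower number from compound 1 to compound 3 (0.14 log units; within the scatter), exchanges one triazole for another and does not touch the kind of change now at hand. Compound 4 `CC(C)C(/C=C1\CCNC1=O)c1ccc(-c2ccc3cccc(F)c3c2)[nH]c1=O` differs from compound 2 in this way: a group of 7 heavy atoms (5 carbon, 1 nitrogen, 1 oxygen; one five-membered non-aromatic ring with 1 hetero atom) in place of a group of 5 heavy atoms (2 carbon, 3 nitrogen; one five-membered aromatic ring with 3 hetero atoms), on a saturated chain carbon bound to an aromatic carbon and a saturated chain carbon. For the measured compounds named here, no measured step speaks to trading an aromatic ring for a non-aromatic one, so the direction rests on judgement alone. A moderate weakening from compound 2 to compound 4 is expected, a 3.3-fold higher number from compound 2 to compound 4 (0.52 log units; beyond the scatter). In this assay compound 4 is therefore estimated at 40 nM, with a range from 8 nM to 200 nM.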

Compound 4, inhibition constant: 2.2 nM
Compound 4: middle estimate off by 18-fold (1.26 log units), on the high side, outside the stated range (below it).
By their numbers in this assay, from the lowest: compound 4; then compound 2; then compounds 3 and 1 (each within the scatter of the next).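

In this assay, exchanging the 4H-1,2,4-triazol-3-yl group for the larger non-aromatic ring gives a 5.5-fold lower number from compound 2 to compound 4 (0.74 log units; beyond the scatter). An aromatic triazole is therefore not required at this saturated chain carbon, something the earlier exchange of one triazole for another could not show. Nothing measured here explains the gain.

Going by these compounds, the ring, its carbonyl and the double bond linking it to the chain all arrive together, so which of them matters remains open. On these data alone, how an amine or a carboxylic acid would compare at this place is also open.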